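The compounds below may be only part of what the source reports. "The series", "measured", "known", "first", "only" and "open" are said of these compounds alone.

Measured in an ADME assay on Vero cells (Chlorocebus sabaeus) for cytotoxicity, read by MTT assay, with a stated time of 72 h; on this read-out higher numbers stand for lower toxicity in this test and lower numbers for higher toxicity in this test:
Compound 1 `CC1(C)C=Cc2c(ccc(C(=O)/C=C/c3ccc(F)c(F)c3)c2O)O1` gives 146000 nM
Compound 2 `CC1(C)C=Cc2c(ccc(C(=O)/C=C/c3ccc(Cl)c(Cl)c3)c2O)O1` gives 142000 nM

For the measured compounds named here, only these two numbers are available, and they cannot be told apart: the one measured step, a 1.0-fold lower number from compound 1 to compound 2 (0.01 log units; within the scatter) stays within the scatter. Going by the values given here, compound 2 therefore stands level with its sole neighbour. Compound 3 `CC1(C)C=Cc2c(ccc(C(=O)/C=C/c3ccc(Cl)cc3Cl)c2O)O1` departs from compound 2 in a single place, 2,4-dichlorophenyl in place of 3,4-dichlorophenyl on a double-bonded chain carbon bound to a double-bonded chain carbon and the rest of the structure is shared. In it, 2,4-dichlorophenyl stands in place of 3,4-dichlorophenyl on a double-bonded chain carbon bound to a double-bonded chain carbon. Among the compounds with values here, the measured step exchanged 3,4-difluorophenyl for 3,4-dichlorophenyl, so it bears only loosely on this change, and no measured compound carries 2,4-dichlorophenyl. On that thin evidence, no step beyond the scatter is expected in this assay and no direction is favoured. The estimated step is a 1.1-fold lower number from compound 2 to compound 3 (0.02 log units; within the scatter) and no more than that is expected. For compound 3 the expected value is 135000 nM with an estimated range from 70000 nM to 230000 nM in this assay.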

Compound 3, half-maximal cytotoxic concentration: 131000 nM
Beside the measured number, compound 3's estimate is 1.0-fold (0.01 log units) above it, within the range that was stated.
By their numbers in this assay, from the lowest: compounds 3, 2 and 1 (each within the scatter of the next).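

Compound 3 shows that in this assay the same atoms joined differently, 2,4-dichlorophenyl in place of 3,4-dichlorophenyl, leave the read-out unresolved, with a 1.1-fold lower number from compound 2 to compound 3 (0.04 log units; within the scatter). The exchange of 2,4-dichlorophenyl for 3,4-difluorophenyl gives a 1.1-fold lower number from compound 1 to compound 3 (0.05 log units; within the scatter), so the earlier finding that the two 3,4-substituted groups could not be told apart now extends to a different arrangement of the chlorines at this place. No supporting measurement is available to explain why these numbers stand level.

All three groups shown at this place are dihalogenated phenyl rings, so how an unsubstituted phenyl, a methoxyphenyl or an aminophenyl would read in this assay remains open. Also open, as far as these compounds go, is whether a change on the shared core, such as a methyl ether in place of the hydroxyl, would separate from these three.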